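The source may report more compounds than this note shows. Statements on the series, on what has been measured and on what is new or still open speak of the compounds shown alone.

In a functional assay on MCF7 cells (Homo sapiens) for antiproliferative activity (on this read-out lower numbers stand for stronger inhibition and higher numbers for weaker inhibition), compound 1 (`CO[C@@H]1[C@@H](O)[C@@H](O)[C@H](Oc2ccc3c(c2C)OC(=O)C(n2cc(-c4ccc(F)cc4F)nn2)C3)OC1(C)C`) reads > 100000 nM as a limit of the assay and not a number. Within the data shown here, only one number exists for the series so far: compound 2 (`CC(=O)Oc1ccc2cc(-n3cc(-c4cc5ccccc5[nH]4)nn3)c(=O)oc2c1C`) gives 76100 nM in this assay, and no step between the two measured compounds is available. Compound 3 (`CO[C@@H]1[C@@H](O)[C@@H](O)[C@H](Oc2ccc3c(c2C)OC(=O)C(n2cc(-c4c[nH]c5ccccc45)nn2)C3)OC1(C)C`) carries 1H-indol-3-yl in place of 2,4-difluorophenyl on an aromatic carbon of the five-membered aromatic ring with 3 nitrogen (1H-indol-3-yl in place of 2,4-difluorophenyl on an aromatic carbon). Among the measured compounds shown here, with compound 2 at 76100 nM as the only guide, a modest move toward stronger inhibition is expected, not a large one. The expected step in this assay is an at least 2.0-fold lower number from compound 1 to compound 3 (0.30 log units; that floor lies within the scatter) and stays a rough estimate, since its starting point is a limit. Compound 3 may well report only a limit too. For compound 3 the estimated value is 50000 nM, with the range expected to run from 10000 nM to 100000 nM at this stage.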

Compound 3, half-maximal inhibitory concentration: 18300 nM
Compound 3: middle estimate off by 2.7-fold (0.44 log units), on the high side, within the range that was stated.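

Among these compounds, with 1H-indol-3-yl in place of 2,4-difluorophenyl, an at least 5.4-fold lower number from compound 1 to compound 3 (0.73 log units; beyond the scatter) stands in this assay as the first readable step, so the group on this aromatic carbon of the five-membered aromatic ring with 3 nitrogen does affect the read-out. On the core of compound 1, compound 3 gives a number, whereas compound 1 itself gives only a limit. The full size of the step cannot be read because its starting point is that limit: the limit of > 100000 nM in this assay, at which 1 of the 3 values shown sits.

As far as these compounds go, whether the change follows the second aromatic ring or the hydrogen-bond donor of 1H-indol-3-yl stays open; a naphthyl group, with two aromatic rings and no such donor, would separate the two. Also open, from the compounds shown here alone, is how this position responds to an amine or a carboxylic acid on the aromatic group.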